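The compounds below may be only part of what the source reports. "The series", "measured", "known", "first", "only" and "open" are said of these compounds alone.

Of the compounds shown here, two have been measured in a functional assay on ileum (Cavia porcellus) for inhibition of cysteinyl leukotriene receptor (Homo sapiens); a higher number here means a weaker inhibitor, a lower number a stronger inhibitor. Compound 1 `CCCc1c(OCCCCOCCCCOc2c(C(C)=O)ccc(OCC(=O)O)c2CCC)ccc(C(C)=O)c1O` gives 500 nM in this assay. Compound 2 `CCCc1c(OCCCOc2ccc3ccc(OCC(=O)O)cc3c2)ccc(C(C)=O)c1O` gives 300 nM in this assay, the lower of the two numbers; the gap to compound 1 lies within the scatter, so the two are read as equivalent. Compound 3 `CCCc1c(OCCCOc2ccc3ccc(OCCCC(=O)O)cc3c2)ccc(C(C)=O)c1O` has not yet been measured. It differs from compound 2 in one place: 2-carboxyethyl in place of carboxy on a saturated chain carbon bound to an oxygen on an aromatic ring. Among the measured compounds shown here, no step between two measured compounds is known in this assay, so the size of such a change cannot be read from the series itself. With nothing to anchor it, the expected step is a 1.7-fold higher number from compound 2 to compound 3 (0.22 log units; within the scatter), that is, a change no larger than the scatter or at most a modest rise. For compound 3 the expected value is therefore 500 nM, with a range from 150 nM to 1500 nM.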

Compound 3, half-maximal inhibitory concentration: 5000 nM
Compound 3: middle estimate off by 10-fold (1.00 log units), on the low side; measured number outside the range, above it.
By their numbers in this assay, from the lowest: compounds 2 and 1 (each within the scatter of the next); then compound 3.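

Among the compounds shown here, at the saturated chain carbon bound to an oxygen on an aromatic ring, the length of the chain carrying the carboxy group proves to matter in this assay: 2-carboxyethyl in place of carboxy gives a 17-fold higher number from compound 2 to compound 3 (1.22 log units; beyond the scatter) and is the first step the series can read. Cut one bond further out, the same change is carboxymethoxy to 3-carboxypropoxy, so this lengthening is not a neutral extension at this position. Nothing on hand accounts for the size of the step.

Still open, on these data alone, is whether the intermediate 2-carboxyethoxy group sits nearer to carboxymethoxy or to 3-carboxypropoxy, which would show whether the rise is gradual or abrupt. Also open, as far as these compounds go, is whether a tetrazole or a primary amide could stand in place of the carboxylic acid on the shorter chain.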